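A few compounds are considered here, and "the series" means these few. Any claim that something is new, unique, unknown or untested is made for them only; others in the source may bear on it.

Of the compounds shown here, two of a shared core have been measured in an assay on HEK293 cells for agonist activity at Toll-like receptor 8 (Homo sapiens), read by spectrophotometry; a higher number here means that more compound is needed for the effect, a lower number that less compound is needed: compound 1 `CCCCNc1nc(N)nc(C)c1CCCCO` and compound 2 `CCCCNc1nc(N)nc(C)c1CCc1ccccc1`. In this assay compound 1 gives 1310 nM, and compound 2 gives 1190 nM, so the two stand within the scatter of each other. For the measured compounds named here, the one step between them, a 1.1-fold lower number from compound 1 to compound 2 (0.04 log units; within the scatter), is therefore a change that leaves the number essentially where it was.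

Compound 3 `CCCCNc1nc(N)nc(C)c1CCCC` is the next compound. Its difference from compound 2 is ethyl in place of phenyl on a saturated chain carbon, two bonds along the chain from an aromatic carbon. Going by the values given here, the only measured step that bears on this place is a 1.1-fold lower number from compound 1 to compound 2 (0.04 log units; within the scatter), which shows that exchanging a 2-hydroxyethyl for a phenyl on that chain carbon left the number in this assay unchanged within the scatter. Nothing measured shows what a shorter alkyl group at this place does, so the expectation rests on that one step alone. Compound 3 is thus expected to come out close to compound 2, with a step of a 1.1-fold higher number from compound 2 to compound 3 (0.04 log units; within the scatter), no larger than the scatter. The estimate for compound 3 in this assay is 1300 nM, with a range from 500 nM to 3500 nM.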

Compound 3, half-maximal effective concentration: 780 nM
For compound 3 the middle estimate is 1.7-fold (0.22 log units) above the measured one; the range from low to high includes it.
By their numbers in this assay, from the lowest: compounds 3, 2 and 1 (each within the scatter of the next).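

In this assay, putting ethyl in place of phenyl on a saturated chain carbon, two bonds along the chain from an aromatic carbon, gives a 1.5-fold lower number from compound 2 to compound 3 (0.18 log units; within the scatter), so removing the six-membered aromatic ring and going from 6 heavy atoms to 2 leaves the number within the scatter. The other new step, a 1.7-fold lower number from compound 1 to compound 3 (0.23 log units; within the scatter), has hydrogen in place of hydroxy on a saturated chain carbon, four bonds along the chain from an aromatic carbon, and it also stays within the scatter, so among these three compounds neither the hydroxy nor the phenyl shows an effect that can be told from the plain alkyl chain of compound 3. Nothing available bears on why these three compounds stand so close together.

As far as these compounds go, whether an amine, a carboxylic acid or a longer chain at this place would give a step beyond the scatter remains open. The three compounds also leave the other places on the shared core untested, as they all carry those places unchanged.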